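The source may report more compounds than this note shows. Statements on the series, on what has been measured and on what is new or still open speak of the compounds shown alone.

Working notes on the pair of dichloro cores. Compound 1 `ClCc1cccc(Cn2cnc3nc(Cl)nc(Cl)c32)c1` and compound 2 `ClCc1ccccc1Cn1cnc2nc(Cl)nc(Cl)c21` share the core and differ only in where the chloromethyl group sits on the benzyl ring. In a functional assay on Hs-578T cells (Homo sapiens) for cytotoxicity, read by sulforhodamine B assay, with a stated time of 48 h (a higher number here means a weaker inhibitor of growth, a lower number a stronger inhibitor of growth), compound 1 gives 2810 nM, and in this assay compound 2 gives 2570 nM; the two values sit within the scatter of each other, so neither can be placed ahead of the other on these two numbers alone. Compound 3 `ClCc1ccccc1Cn1cnc2ncnc(Cl)c21` is not yet measured and keeps the benzyl arrangement of compound 2; the change from compound 2 to compound 3 is hydrogen in place of chloro on an aromatic carbon. Within the data shown here, no measured pair shows this change, so its size is unknown from the data. A modest weakening is expected, since one of the two chloro groups on the core is lost, with the step from compound 2 to compound 3 estimated at a 1.6-fold higher number from compound 2 to compound 3 (0.19 log units; within the scatter). Compound 3 is expected to give about 4000 nM in this assay, with a range from 1500 nM to 12000 nM.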

Compound 3, concentration for total growth inhibition: 6020 nM
Estimate against measurement, compound 3: 1.5-fold (0.18 log units) below; the measured number falls inside the stated range.
By their numbers in this assay, from the lowest: compounds 2 and 1 (each within the scatter of the next); then compound 3.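

Hydrogen in place of chloro on the aromatic carbon between two ring nitrogen atoms gives a 2.3-fold higher number from compound 2 to compound 3 (0.37 log units; beyond the scatter) in this assay and is the first single change in the series to pass beyond the scatter, whereas the two placements of the chloromethyl group in compound 1 and compound 2 could not be told apart. This chloro group therefore contributes to growth inhibition with the benzyl arrangement of compound 2, although the step is modest. Nothing available explains the size of this step.

Going by these compounds, whether an amine or a methoxy group on this carbon would match chloro or fall nearer to hydrogen remains open. Also open, on these data alone, is whether the same step holds with the chloromethyl placement of compound 1, and what the remaining chloro group on the core contributes.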